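Chain variation at the aromatic nitrogen: compound 4

This account rests on a few compounds, and the source may have more. Where it says the series, first, only, none or still open, it means among the compounds named here.

Measured so far, in a functional assay on SH-SY5Y cells (Homo sapiens) for cytotoxicity, read by MTT assay, with a stated time of 72 h; a higher number here means a weaker inhibitor, a lower number a stronger inhibitor:
compound 1 `CN(C)CCCCCn1c2c(c3ccccc31)C(=O)c1c[n+]([O-])c3ccccc3c1C2=O` gives 370 nM
compound 2 `O=C1c2c[n+]([O-])c3ccccc3c2C(=O)c2c1c1ccccc1n2CCCCn1ccnc1` gives 130 nM
compound 3 `O=C1c2c[n+]([O-])c3ccccc3c2C(=O)c2c1c1ccccc1n2Cc1cn(CC(O)CO)nn1` reports only a limit, > 1000 nM.

Of the two numbers, compound 1 holds the higher; the step of a 2.8-fold lower number from compound 1 to compound 2 (0.45 log units; beyond the scatter) is beyond the scatter. The step of an at least 2.7-fold higher number from compound 1 to compound 3 (0.43 log units; beyond the scatter) rests on the limit (the limit of > 1000 nM in this assay, at which 1 of the 3 values shown sits).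

Compound 4 `O=C1c2c[n+]([O-])c3ccccc3c2C(=O)c2c1c1ccccc1n2CCN1CCCC1` differs from compound 1 by pyrrolidin-1-yl in place of 3-(dimethylamino)propyl on a saturated chain carbon, two bonds along the chain from an aromatic nitrogen. Within the data shown here, the step that bears on it is the one from compound 1 to compound 2, where a ring entered on the chain and the number fell modestly. Compound 4 keeps a tertiary amine on a shorter chain and brings a saturated ring; a step in this assay near or a little below compound 1 is expected, a 1.2-fold lower number from compound 1 to compound 4 (0.09 log units; within the scatter). Compound 4 is thus estimated at 300 nM, range 120 nM to 800 nM.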

Compound 4, half-maximal inhibitory concentration: 520 nM
Compound 4: middle estimate off by 1.7-fold (0.24 log units), on the low side, and the stated range covers the measured number.
By their numbers in this assay, from the lowest: compound 2; then compounds 1 and 4 (each within the scatter of the next). At a limit, above all of these: compound 3.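

In this assay, pyrrolidin-1-yl in place of 3-(dimethylamino)propyl on a saturated chain carbon, two bonds along the chain from an aromatic nitrogen, gives no separation, with a 1.4-fold higher number from compound 1 to compound 4 (0.15 log units; within the scatter). A ring on the chain is therefore not enough on its own for the lower number, since pyrrolidin-1-yl in place of 2-(1H-imidazol-1-yl)ethyl gives a 4.0-fold higher number from compound 2 to compound 4 (0.60 log units; beyond the scatter). The step of an at least 1.9-fold lower number from compound 3 to compound 4 (0.28 log units; that floor lies within the scatter) rests on a limit and cannot be read: the limit of > 1000 nM in this assay, at which 1 of the 4 values shown sits.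

From the compounds shown here alone, whether the ring type or the chain length sets the gap between the two ring-bearing chains remains open. A 4-(pyrrolidin-1-yl)butyl chain or a morpholine ring on the shorter chain would bear on this.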